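A Chloro Added to the Amide-Side Phenyl

The source may hold more compounds than are shown below. What is called first, only, known or untested is meant among the compounds shown, and "the series" means these compounds.

For the measured compounds named here, compound 1 `O=C(CCN1CCN(c2cccc(Cl)c2)CC1)N1CCN(c2ccccc2)CC1` gives the lower of the two numbers known in an assay on cells for displacement of a labelled ligand from 5-hydroxytryptamine receptor 7 (Homo sapiens), read by scintillation counting, with a stated time of 30 min (on this read-out higher numbers stand for weaker inhibition and lower numbers for stronger inhibition), where compound 1 gives 32.7 nM. Going by the values given here, its only measured neighbour, compound 2 `CCOc1ccccc1N1CCN(CCC(=O)N2CCN(c3ccccc3)CC2)CC1`, carries 2-ethoxyphenyl in place of 3-chlorophenyl on an amine nitrogen in a ring; in this assay compound 2 gives 80.3 nM, and the step of a 2.5-fold higher number from compound 1 to compound 2 (0.39 log units; beyond the scatter) is modest though beyond the scatter. Compound 3 `O=C(CCN1CCN(c2cccc(Cl)c2)CC1)N1CCN(c2cccc(Cl)c2)CC1` differs from compound 1 by chloro in place of hydrogen on an aromatic carbon, on an aromatic carbon of a six-membered aromatic ring of carbon only, meta to a large group; cut one bond further out, this reads phenyl to 3-chlorophenyl. Among the compounds with values here, no measured step touches this ring: the one step known concerns the aryl group on the other nitrogen in a ring. Accordingly no step beyond the scatter is expected, and the estimated change is a 1.1-fold higher number from compound 1 to compound 3 (0.03 log units; within the scatter). Compound 3 is therefore expected to give about 35 nM, within 12 nM to 100 nM.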

Compound 3, inhibition constant: 2760 nM
The estimate for compound 3 lay 79-fold (1.90 log units) below the measured number, outside the stated range (above it).
By their numbers in this assay, from the lowest: compound 1; then compound 2; then compound 3.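

In this assay, for the compounds shown here, the phenyl that had no measured step turns out to be far from indifferent to substitution: phenyl to 3-chlorophenyl gives an 84-fold higher number from compound 1 to compound 3 (1.93 log units; beyond the scatter), a large step from the change of one hydrogen to one chloro. The earlier step, a 2.5-fold higher number from compound 1 to compound 2 (0.39 log units; beyond the scatter), swapped a whole aryl group on the other ring nitrogen and was only modest, so the compounds shown tolerate that change far better than this single added atom. Nothing at hand explains why this chloro weakens inhibition so sharply.

As far as these compounds go, whether a fluoro, a methyl or a methoxy group at this place would give a step of similar size stays open. So does whether the step would hold with 2-ethoxyphenyl on the other ring nitrogen, as in compound 2, in place of 3-chlorophenyl.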